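A few compounds are considered here, and "the series" means these few. Any claim that something is new, unique, unknown or untested is made for them only; others in the source may bear on it.

Measured so far:
- compound 1 `COc1ccccc1Oc1cncc(C2=CC3CNCC(C2)C3)c1`: 1 nM
- compound 2 `C1=C(c2ccncc2)CC2CNCC1C2`: 56 nM

Of the compounds shown here, two have been measured in an in vitro assay on SH-EP1 cells for displacement of a labelled ligand from Neuronal acetylcholine receptor; alpha4/beta2 (Homo sapiens); a higher number here means a weaker inhibitor, a lower number a stronger inhibitor. Compound 1 gives 1 nM, the lowest of the two numbers; its nearest neighbour is compound 2, which in this assay gives 56 nM, a gap that lies beyond the scatter. Going by the values given here, no pair differing in a single place has yet been measured, so no step size is known from the data.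

Compound 3 `C1=C(c2cncc(Oc3ccccc3)c2)CC2CNCC1C2` differs from compound 1 by one change: hydrogen in place of methoxy on an aromatic carbon. The 2-methoxyphenyl of compound 1 becomes a plain phenyl. Among the compounds with values here, with no measured step to lean on, a modest rise in the number is expected, small but probably at the edge of the scatter or a little beyond it.

Compound 3 is expected to give 3 nM, within 1 nM to 15 nM, a step estimated as a 3.0-fold higher number from compound 1 to compound 3 (0.48 log units; beyond the scatter).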

Compound 3, inhibition constant: 0.7 nM
Compound 3: the middle estimate sits 4.3-fold (0.63 log units) above what was measured; the whole stated range lies above it.
By their numbers in this assay, from the lowest: compounds 3 and 1 (each within the scatter of the next); then compound 2.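

Hydrogen in place of methoxy on an aromatic carbon, ortho to a large group, gives in this assay a 1.4-fold lower number from compound 1 to compound 3 (0.15 log units; within the scatter). Going by these compounds alone, this is the first single-place step, and it shows that the 2-methoxyphenyl to phenyl change leaves the number within the scatter, so the methoxy is not needed for a value at this level on this core. No available measurement speaks to the reason for this outcome.

The compounds shown leave open whether other groups at this position, such as fluorine, hydroxyl, an amine or a longer alkoxy chain, would also stay within the scatter. They also leave open whether the same replacement would behave alike elsewhere on this aromatic ring.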